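The source may report more compounds than this note shows. Statements on the series, on what has been measured and on what is new or still open speak of the compounds shown alone.

Measured in a functional assay on Bel7402/5-FU cells (Homo sapiens) for antiproliferative activity, read by MTT assay, with a stated time of 72 h; a lower number here means a stronger inhibitor, a higher number a weaker inhibitor:
- compound 1 `C=C1C(=O)O[C@H]2[C@H]1CC/C(COC(=O)Cn1cc(F)c(=O)n(Cc3ccc(F)cc3)c1=O)=C\CC[C@@]1(C)O[C@@H]21`: 1140 nM
- compound 2 `C=C1C(=O)O[C@H]2[C@H]1CC/C(COC(=O)Cn1cc(F)c(=O)n(Cc3ccc(Cl)cc3)c1=O)=C\CC[C@@]1(C)O[C@@H]21`: 2420 nM

Of the two, compound 2 has the higher number, 2420 nM, and is thus the weaker inhibitor. The next analogue, compound 3 `C=C1C(=O)O[C@H]2[C@H]1CC/C(COC(=O)Cn1cc(F)c(=O)n(Cc3ccc(Br)cc3)c1=O)=C\CC[C@@]1(C)O[C@@H]21`, has not yet been measured. It differs from compound 2 by bromo in place of chloro on an aromatic carbon, which turns 4-chlorobenzyl into 4-bromobenzyl, para to a large group. Going by the values given here, only one measured step bears on this change, the other halogen exchange: a 2.1-fold higher number from compound 1 to compound 2 (0.33 log units; beyond the scatter), a modest step just beyond the scatter. On that single step, a further modest rise in this assay is expected, although a result within the scatter of compound 2 remains possible. The expected change is a 1.3-fold higher number from compound 2 to compound 3 (0.11 log units; within the scatter). Compound 3 is estimated at 3100 nM, with an expected range from 1400 nM to 6000 nM.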

Compound 3, half-maximal inhibitory concentration: 3240 nM
For compound 3 the middle estimate is 1.0-fold (0.02 log units) below the measured one, within the range that was stated.
By their numbers in this assay, from the lowest: compound 1; then compounds 2 and 3 (each within the scatter of the next).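

In this assay, bromo in place of chloro gives a 1.3-fold higher number from compound 2 to compound 3 (0.13 log units; within the scatter), so at this place on the aromatic ring, para to a large group, compound 2 and compound 3 cannot be told apart, something the fluoro-to-chloro step alone could not show. Bromo in place of fluoro gives a 2.8-fold higher number from compound 1 to compound 3 (0.45 log units; beyond the scatter), so compound 1 now stands apart beyond the scatter from both heavier-halogen analogues, while the exchange beyond chloro adds no separable step. Nothing given here accounts for these differences.

The compounds shown carry only halogens at this place, so it remains open how a methoxy group, a nitrile or an amine would read here, or a benzyl group with no substituent at all. From the compounds shown here alone, whether the same halogen order would hold with the halogen elsewhere on the aromatic ring also remains open.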